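Compound 3: isopropyl in place of methyl

The source may hold more compounds than are shown below. What is called first, only, known or untested is meant among the compounds shown, and "the series" means these compounds.

In an ADME assay on microsomes (Homo sapiens) for metabolic stability (on this read-out lower numbers stand for slow clearance and higher numbers for fast clearance), compound 1 `CNC(=O)[C@@H]1CCCN1S(=O)(=O)c1ccc(Cl)c(COc2cccc3c(-c4nccn4C)cc(C)nc23)c1Cl` gives 117 mL/min/kg and compound 2 `CNC(=O)[C@@H]1CCCN1S(=O)(=O)c1ccc(Cl)c(COc2cccc3c(-c4ccncc4)cc(C)nc23)c1Cl` gives 217 mL/min/kg. These two values lie within the scatter of each other, so no order can be read between them.

Compound 3 `CNC(=O)[C@@H]1CCCN1S(=O)(=O)c1ccc(Cl)c(COc2cccc3c(-c4ccncc4)cc(C(C)C)nc23)c1Cl` differs from compound 2 in one place: isopropyl in place of methyl on an aromatic carbon. This is isopropyl in place of methyl on an aromatic carbon, next to the ring nitrogen and meta to the pyridin-4-yl group.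

Among the measured compounds shown here, only one measured step is available: a 1.9-fold higher number from compound 1 to compound 2 (0.27 log units; within the scatter). It lies at a different place, with pyridin-4-yl in place of 1-methyl-1H-imidazol-2-yl, and stays within the scatter. For the measured compounds named here, no measured step covers the methyl group, so the data give no direction for this change. The expectation in this assay therefore stays close to compound 2 at 217 mL/min/kg, with no shift beyond the scatter.

The expected step is a 1.1-fold higher number from compound 2 to compound 3 (0.03 log units; within the scatter), which is an estimate and not a measured change.

For compound 3 the estimated clearance is 230 mL/min/kg, with an expected range from 120 mL/min/kg to 400 mL/min/kg.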

Compound 3, clearance: 333 mL/min/kg
The estimate for compound 3 lay 1.4-fold (0.16 log units) below the measured number; the range from low to high includes it.
By their numbers in this assay, from the lowest: compounds 1, 2 and 3 (each within the scatter of the next, the first and the last beyond it).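

In this assay, the aromatic carbon next to the ring nitrogen now has its first measured step: with the pyridin-4-yl group held in place, isopropyl in place of methyl gives a 1.5-fold higher number from compound 2 to compound 3 (0.19 log units; within the scatter). On this read-out compound 2 and compound 3 therefore cannot be told apart, and this position has so far shown no response beyond the scatter to this one exchange of alkyl groups. Nothing measured bears on what lies behind this result.

Going by these compounds, it remains open whether an amine, a carboxylic acid or a longer alkyl chain on this same aromatic carbon would move the clearance beyond the scatter, since a single step within the scatter does not describe the position as a whole. On these data alone, it also remains open whether isopropyl in place of methyl reads the same when the 1-methyl-1H-imidazol-2-yl group of compound 1 replaces the pyridin-4-yl group.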